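Replacing Nitro with Cyano in Compound 1

The source may report more compounds than this note shows. Statements on the series, on what has been measured and on what is new or still open speak of the compounds shown alone.

In a functional assay on T98G cells (Homo sapiens) for inhibition, read by MTT assay, with a stated time of 72 h (on this read-out higher numbers stand for weaker inhibition and lower numbers for stronger inhibition), compound 1 `CC1(C)CC(NC(=S)Nc2ccc([N+](=O)[O-])cc2)c2cc(Br)ccc2O1` gives 5000 nM. Within the data shown here, its fluoro counterpart, compound 2 `CC1(C)CC(NC(=S)Nc2ccc([N+](=O)[O-])cc2)c2cc(F)ccc2O1`, gives 5000 nM, so the two stand level and compound 1 has only this one measured neighbour. Compound 3 `CC1(C)CC(NC(=S)Nc2ccc(C#N)cc2)c2cc(Br)ccc2O1` has not yet been measured. It keeps the bromo of compound 1 and differs at another place: cyano in place of nitro on an aromatic carbon, (cyano in place of nitro on an aromatic carbon). The change lies on a six-membered aromatic ring of carbon only, para to a large group.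

Among the measured compounds shown here, only one measured step exists, no change at the digits printed from compound 1 to compound 2 (within the scatter), and it is fluoro in place of bromo on an aromatic carbon. For the measured compounds named here, that step touches a different place, and no measured pair shows what exchanging the nitro does, so it is a weak guide. The expectation therefore starts from compound 1 at 5000 nM, and no shift beyond the scatter is expected in this assay in either direction. The expected step is no change at the digits printed from compound 1 to compound 3 (within the scatter). Compound 3 is estimated at 5000 nM, with an expected range from 1500 nM to 15000 nM.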

Compound 3, half-maximal inhibitory concentration: 24000 nM
Estimate against measurement, compound 3: 4.8-fold (0.68 log units) below, outside the stated range (above it).
By their numbers in this assay, from the lowest: compounds 1 and 2 (each within the scatter of the next); then compound 3.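

In this assay, the place on the six-membered aromatic ring that holds the nitro responds to exchange, with a 4.8-fold higher number from compound 1 to compound 3 (0.68 log units; beyond the scatter) on going to cyano. Among these compounds, the only earlier step, no change at the digits printed from compound 1 to compound 2 (within the scatter), came from putting fluoro in place of bromo, so this is the first sign that a single change on these compounds can move the number at all, and here it moves towards weaker inhibition. The step is modest and rests on one pair, and nothing measured here accounts for it.

What the compounds shown leave open is whether the exchange of nitro for cyano would give a step of similar size on compound 2, as bromo and fluoro have been compared only with the nitro in place. Also open, as far as these compounds go, is how an amine, a carboxylic acid or a methoxy group would fare on this same aromatic carbon, and whether any group there could bring the number below that of compound 1.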